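Dropping the Dimethylamino Group: What to Expect

A few compounds are considered here, and "the series" means these few. Any claim that something is new, unique, unknown or untested is made for them only; others in the source may bear on it.

Of the compounds shown here, two have numbers so far. Compound 1 `c1ccc(-c2ccc(-c3ccc(-c4nc5ccccc5[nH]4)cc3)cc2)cc1` gives 39700 nM in a functional assay on KB cells (Homo sapiens) for inhibition, read by sulforhodamine B assay; on this read-out lower numbers stand for stronger inhibition of growth and higher numbers for weaker inhibition of growth. Compound 2 `Cc1ccc2[nH]c(-c3ccc(-c4ccc(-c5ccc(N(C)C)cc5)cc4)cc3)nc2c1` gives 6240 nM in this assay, the lowest of the two numbers, and its gap to compound 1 lies beyond the usual scatter.

Compound 3 `Cc1ccc2[nH]c(-c3ccc(-c4ccc(-c5ccccc5)cc4)cc3)nc2c1` is still to be measured. It differs from compound 2 in one place: hydrogen in place of dimethylamino on an aromatic carbon. Within the data shown here, no pair of measured compounds differing in a single place exists here, so the expectation rests on the fact that compound 1, which also carries no dimethylamino group, gives the weaker result of 39700 nM. On that basis the step is expected to go upward, toward weaker growth inhibition, and to exceed the scatter: a 4.8-fold higher number from compound 2 to compound 3 (0.68 log units; beyond the scatter). For compound 3 the concentration for half-maximal growth inhibition is therefore estimated at 30000 nM, with a range from 10000 nM to 90000 nM.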

Compound 3, concentration for 50% growth inhibition: 32100 nM
For compound 3 the middle estimate is 1.1-fold (0.03 log units) below the measured one; the measured number falls inside the stated range.
By their numbers in this assay, from the lowest: compound 2; then compounds 3 and 1 (each within the scatter of the next).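

Taking away the dimethylamino group gives a 5.1-fold higher number from compound 2 to compound 3 (0.71 log units; beyond the scatter) in this assay, the first comparison here that changes this position alone. It ties the better growth inhibition of compound 2 to the 4-(dimethylamino)phenyl end, at least in this pair. The methyl group on the core, by contrast, makes no readable difference, with a 1.2-fold lower number from compound 1 to compound 3 (0.09 log units; within the scatter), and no measurement offers an explanation for either result.

As far as these compounds go, whether the nitrogen or simply a group at this place matters remains open: a plain amino group, a methoxy group or a carboxylic acid in the same place would help separate these possibilities. It is also unknown whether the methyl group stays without effect when the dimethylamino group is present.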